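Hydrogen in place of methoxy on compound 3

The source may report more compounds than this note shows. Statements on the series, on what has been measured and on what is new or still open speak of the compounds shown alone.

For the measured compounds named here, in a functional assay on NSCLC cells (Homo sapiens) for cytotoxicity, read by sulforhodamine B assay, with a stated time of 48 h (a higher number here means a weaker inhibitor of growth, a lower number a stronger inhibitor of growth), compound 3 (`COc1ccc2c(c1)/C(=C\c1c(OC)nc3sc(C)cn13)C(=O)N2`) gives 1490 nM and stands second highest of the three numbers so far. Compound 1 (`COc1ccc2c(c1)/C(=C/c1c(-c3ccncc3)nc3sccn13)C(=O)N2C`) gives a lower number (550 nM) and compound 2 (`COc1nc2sc(C)cn2c1C=C1C(=O)N(C)c2ccccc21`) a higher one (9500 nM), both gaps lying beyond the scatter.

Compound 4 (`COc1nc2sc(C)cn2c1/C=C1/C(=O)Nc2ccccc21`) follows from compound 3 by one change, hydrogen in place of methoxy on an aromatic carbon. Going by the values given here, no measured pair isolates this change, so the evidence is indirect and weak. Compound 2 has no methoxy on its six-membered aromatic ring of carbon only and gives 9500 nM there, whereas compound 3 has one and gives 1490 nM in the same read-out. These two compounds also differ elsewhere. A moderate move toward a higher number, meaning weaker growth inhibition, is therefore expected. The expected change is a 2.3-fold higher number from compound 3 to compound 4 (0.37 log units; beyond the scatter) with a real chance of none beyond the scatter. The estimate for compound 4 is 3500 nM (expected range 1300 nM to 9500 nM).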

Compound 4, concentration for 50% growth inhibition: 5680 nM
For compound 4 the middle estimate is 1.6-fold (0.21 log units) below the measured one; the range from low to high includes it.
By their numbers in this assay, from the lowest: compound 1; then compound 3; then compounds 4 and 2 (each within the scatter of the next).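

In this assay, for the compounds shown here, this pair gives the first direct reading of the position, with hydrogen in place of methoxy as the only change: a 3.8-fold higher number from compound 3 to compound 4 (0.58 log units; beyond the scatter). Going by these compounds alone, the methoxy on the six-membered aromatic ring of carbon only therefore matters for growth inhibition in this pair, which the earlier compounds could suggest only through structures that also differed elsewhere. No measurement at hand accounts for this loss of growth inhibition.

From the compounds shown here alone, it remains open whether ethoxy, a hydroxyl group, fluorine or an amine at the same place would behave like methoxy, like hydrogen or like neither. Going by these compounds, it is also open whether the same change would have a similar size on the core of compound 1, which also carries a methoxy group.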